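Replacing anilino with trifluoromethyl: what the growth data suggest

The compounds below may be only part of what the source reports. "The series", "measured", "known", "first", "only" and "open" are said of these compounds alone.

In a functional assay on HeLa cells (Homo sapiens) for antiproliferative activity, read by spectrophotometry, with a stated time of 2 days (on this read-out higher numbers stand for weaker inhibition of growth and lower numbers for stronger inhibition of growth), compound 3 `CN(c1cccc2c1CN(c1nc(Nc3ccc(Nc4ccccc4)cc3)ncc1C(F)(F)F)C2)S(C)(=O)=O` gives 7300 nM and so sits within the scatter of compound 2 `Cc1ccc(Nc2ncc(C(F)(F)F)c(N3Cc4cccc(N(C)S(C)(=O)=O)c4C3)n2)c(Cl)c1` at 10900 nM but lower than compound 1 `COc1ccc(C(F)(F)F)cc1Nc1ncc(C(F)(F)F)c(N2Cc3cccc(N(C)S(C)(=O)=O)c3C2)n1` at 17200 nM by more than the scatter. Compound 4 `CN(c1cccc2c1CN(c1nc(Nc3ccc(C(F)(F)F)cc3)ncc1C(F)(F)F)C2)S(C)(=O)=O` carries trifluoromethyl in place of anilino on an aromatic carbon, para to a large group (trifluoromethyl in place of anilino on an aromatic carbon). No measurement tests this exchange directly. Among the measured compounds shown here, the only measured step (a 1.6-fold lower number from compound 1 to compound 2 (0.20 log units; within the scatter)) swaps one substituted phenyl for another and stays within the scatter. With so little to go on, the estimated step (a 1.5-fold higher number from compound 3 to compound 4 (0.18 log units; within the scatter)) in this assay is expected to stay within the scatter too, leaning towards a higher number. Compound 4 is expected to give 11000 nM (estimated range 4500 nM to 26000 nM).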

Compound 4, concentration for 50% growth inhibition: > 30000 nM
Compound 4: no number, only a limit; the forecaster's own chance of this, stated with the estimate: 8%; at least 2.7-fold (0.43 log units) between middle value and limit.
By their numbers in this assay, from the lowest: compounds 3, 2 and 1 (each within the scatter of the next, the first and the last beyond it). At a limit, above all of these: compound 4.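

In this assay, trifluoromethyl in place of anilino on an aromatic carbon gives an at least 4.1-fold higher number from compound 3 to compound 4 (0.61 log units; beyond the scatter), so this position does respond to what it carries. The wider comparisons give an at least 2.7-fold higher number from compound 2 to compound 4 (0.43 log units; beyond the scatter), which also lies beyond the scatter, and an at least 1.7-fold higher number from compound 1 to compound 4 (0.24 log units; that floor lies within the scatter), which cannot settle a difference. Compound 4 gives no number, only a limit of the assay: the limit of > 30000 nM in this assay, at which 1 of the 4 values shown sits.

Going by these compounds, it remains open whether an amine or a phenoxy group at this position would retain the growth inhibition seen with anilino. On these data alone, how far compound 4 lies past its limit also remains open.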